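This account rests on a few compounds, and the source may have more. Where it says the series, first, only, none or still open, it means among the compounds named here.

Compound 1 `Cc1nn(C)c(C(=O)NCc2ccc(Oc3ccc(Cl)cc3)cc2)c1Cl`: in a toxicity assay on MCF-10A cells (Homo sapiens) for cytotoxicity (on this read-out higher numbers stand for weaker inhibition and lower numbers for stronger inhibition), compound 1 gives 50000 nM.
Compound 2 `Cn1ncc(Cl)c1C(=O)NCc1ccc(Oc2ccc(Cl)cc2)cc1`: in this assay compound 2 gives > 50000 nM, which is a limit of the assay and not a number.

Compound 2 therefore stands at the limit, with only a range known for it. For the measured compounds named here, the single measured step, a number no lower from compound 1 to compound 2 (the limit leaves the size open), runs from a number into the limit, so its size cannot be read, as the limit of > 50000 nM in this assay, at which 1 of the 2 values shown sits, shows. Compound 3 `Cn1ncc(Cl)c1C(=O)NCc1ccc(Oc2ccc(Cl)nc2)cc1` differs from compound 2 by 6-chloropyridin-3-yl in place of 4-chlorophenyl on an oxygen on an aromatic ring. Going by the values given here, no measured step concerns an exchange of this kind; the one step available describes a different change and so gives no guide to direction or size. With nothing more to draw on, no shift beyond the usual scatter is expected in this assay, and compound 3 will most likely also sit at the limit. Compound 3 is thus estimated at 50000 nM, within 25000 nM to 100000 nM. The expected step of a number no higher from compound 2 to compound 3 (the limit leaves the size open) means essentially no change.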

Compound 3, half-maximal inhibitory concentration: > 50000 nM
Compound 3: a limit, no number (the forecaster's own chance of this, stated with the estimate: 70%); the middle value sits exactly at the limit.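

Compound 2 and compound 3 both give a limit of the assay and not a number, so no step can be read between them: the limit of > 50000 nM in this assay, at which 2 of the 3 values shown sit. The compounds shown leave open whether 6-chloropyridin-3-yl in place of 4-chlorophenyl shifts the read-out in this assay at all.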